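The compounds below may be only part of what the source reports. "The series", "measured", "known", "first", "only" and "open" are said of these compounds alone.

Series notes.

Three compounds carry the same amide link to a para-substituted aromatic ring; they differ in the chain on the ring oxygen and in the group on the core. Compound 2 `CCCOc1ccc(C(=O)Nc2cccc(C)n2)cc1` gives 11100 nM in an in vitro assay on HEK-tsA201 cells for antagonist activity at Neuronal acetylcholine receptor; alpha3/beta4 (Homo sapiens), read by fluorescence and calcium flux; a lower number here means a stronger inhibitor, a higher number a weaker inhibitor. Compound 1 `C=CCOc1ccc(C(=O)Nc2cccc(C)n2)cc1` gives 31700 nM in this assay; the change is vinyl in place of ethyl on a saturated chain carbon bound to an oxygen on an aromatic ring, and the step is a 2.9-fold higher number from compound 2 to compound 1 (0.46 log units; beyond the scatter). Compound 3 `CCCNc1cccc(NC(=O)c2ccc(OCCC)cc2)n1` gives 12600 nM in this assay; here the cores differ by propylamino in place of methyl on an aromatic carbon, and the step is a 1.1-fold higher number from compound 2 to compound 3 (0.06 log units; within the scatter), so compound 2 and compound 3 are not told apart by this assay.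

Compound 4 `C=CCOc1ccc(C(=O)Nc2cccc(NCCC)n2)cc1` has not been measured in this assay. It differs from compound 3 by vinyl in place of ethyl on a saturated chain carbon bound to an oxygen on an aromatic ring, the same change as that from compound 2 to compound 1, made on the same place, on a saturated chain carbon bound to an oxygen on an aromatic ring; only the core differs, as described for compound 3 against compound 2. Going by the values given here, compound 1 and compound 4 have no step counted between them beyond what their structures show.

Expectation: the core change left compound 2 and compound 3 within the scatter of each other. The measured step for this chain change is a 2.9-fold higher number from compound 2 to compound 1 (0.46 log units; beyond the scatter). The step from compound 3 to compound 4 is expected to resemble it, so a 2.9-fold higher number from compound 3 to compound 4 (0.46 log units; beyond the scatter) is estimated. For compound 4 the expected value in this assay is 36000 nM, estimated to fall between 18000 nM and 72000 nM. This rests on two measured pairs only; a second occurrence of the change is not yet available to test it.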

Compound 4, half-maximal inhibitory concentration: 11700 nM
Compound 4: the middle estimate sits 3.1-fold (0.49 log units) above what was measured; measured number outside the range, below it.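

On the core of compound 3, propyl to allyl on the ring oxygen gives a 1.1-fold lower number from compound 3 to compound 4 (0.03 log units; within the scatter), so compound 3 and compound 4 are not told apart, and the step seen on the core of compound 2 does not carry over: the same change on two cores in this assay, a 2.9-fold higher number (0.46 log units; beyond the scatter) from compound 2 to compound 1 and a 1.1-fold lower number (0.03 log units; within the scatter) from compound 3 to compound 4, 3.1-fold (0.49 log units) apart, beyond the scatter of two such steps

Read the other way, propylamino in place of methyl on an aromatic carbon gives a 2.7-fold lower number from compound 1 to compound 4 (0.43 log units; beyond the scatter) among the allyloxy compounds, while the same swap left the propoxy compounds compound 2 and compound 3 within the scatter: the same change on two cores in this assay, a 1.1-fold higher number (0.06 log units; within the scatter) from compound 2 to compound 3 and a 2.7-fold lower number (0.43 log units; beyond the scatter) from compound 1 to compound 4, 3.1-fold (0.49 log units) apart, beyond the scatter of two such steps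

In this set, then, the size of the chain change depends on the core that carries it, and a step measured on one core is a poor guide to the other; the four compounds form a single comparison, so they do not show why the two steps part, nor whether this holds beyond these compounds.

Going by these compounds, it remains open whether a longer chain on the ring oxygen, such as butoxy, or a cyclopropylmethyl group there would also respond differently on the two cores. Also open, on these data alone, is whether a smaller amine on the aromatic carbon, such as ethylamino, would behave like propylamino or like methyl when paired with allyloxy.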